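From cyclohexyl to cyclopentyl on a carbonyl carbon

The source may hold more compounds than are shown below. What is called first, only, known or untested is meant among the compounds shown, and "the series" means these compounds.

Of the compounds shown here, three have been measured so far. In a functional assay on Daoy cells (Homo sapiens) for antiproliferative activity, read by trypan blue exclusion and crystal violet staining, with a stated time of 72 h (a higher number here means a weaker inhibitor, a lower number a stronger inhibitor), compound 1 `O=C(NCc1ccc2cccnc2c1O)C1CCCCC1` gives 720 nM, while compound 2 `CCCC(=O)NC(c1ccc(C)cc1)c1cc(Cl)c2cccnc2c1O` gives 100 nM. Compound 3 `O=C(NC(c1ccc(Cl)cc1Cl)c1ccc2cccnc2c1O)C1CCCCC1` gives 240 nM, which places it in the middle of the three numbers, with compound 1 above it and compound 2 below it.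

The next molecule is compound 4 `O=C(NC(c1ccc(Cl)cc1Cl)c1ccc2cccnc2c1O)C1CCCC1`, which keeps everything in compound 3 except one group. Cyclopentyl stands in place of cyclohexyl on a carbonyl carbon: cyclopentyl in place of cyclohexyl on a carbonyl carbon.

Going by the values given here, only one measured step links two compounds that differ in a single place, a 3.0-fold lower number from compound 1 to compound 3 (0.48 log units; beyond the scatter). This is a modest change, but it occurs elsewhere in the molecule and leaves the cyclohexyl group untouched, so it bears on the new change only indirectly. Compound 2 differs from compound 3 in more than one place, so its value cannot isolate the effect of this swap. Among the compounds with values here, no measured pair shows what replacing cyclohexyl with cyclopentyl does in this assay.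

With no evidence for a shift in either direction, the expected step, a 1.1-fold higher number from compound 3 to compound 4 (0.03 log units; within the scatter), stays within the scatter. For compound 4 the estimated value is 260 nM, with an expected range from 110 nM to 600 nM.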

Compound 4, half-maximal inhibitory concentration: 150 nM
Beside the measured number, compound 4's estimate is 1.7-fold (0.24 log units) above it, within the range that was stated.
By their numbers in this assay, from the lowest: compounds 2, 4 and 3 (each within the scatter of the next, the first and the last beyond it); then compound 1.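

Going by these compounds alone, this is the first step measured at the carbonyl carbon itself, as the earlier step from compound 1 to compound 3 changed another part of the molecule. In this assay, cyclopentyl in place of cyclohexyl gives a 1.6-fold lower number from compound 3 to compound 4 (0.20 log units; within the scatter) and so compound 3 and compound 4 cannot be told apart in this assay. With the 2,4-dichlorophenyl group and the rest of the molecule held fixed, this position therefore accepts the five-membered carbon ring as well as the six-membered one, and nothing available gives any further account of this result.

This single pair cannot show whether the two rings would also match in another setting, such as the core of compound 1, which has hydrogen in place of the 2,4-dichlorophenyl group, or the chlorinated core of compound 2. It also leaves open how far this position can be pushed, for example with a smaller cyclopropyl ring, a flat phenyl ring, or a cyclohexyl ring carrying an amine or a carboxylic acid on the same carbonyl carbon.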